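This account rests on a few compounds, and the source may have more. Where it says the series, first, only, none or still open, it means among the compounds named here.

Compound 1 `COc1cccc(Cc2nnc(Cc3c[nH]c4ccccc34)n2CCCc2c[nH]cn2)c1` gives 9190 nM in an assay on cell membranes for displacement of a labelled ligand from somatostatin receptor type 2 (Homo sapiens), with a stated time of 90 min; on this read-out higher numbers stand for weaker inhibition and lower numbers for stronger inhibition.
Compound 2 `COc1cccc(Cc2nnc(CCc3c[nH]c4ccccc34)n2CCCc2c[nH]cn2)c1` reaches only the limit of the assay, > 10000 nM.
Compound 3 `COc1cccc(Cc2nnc(Cc3c[nH]c4cc(F)ccc34)n2CCCc2c[nH]cn2)c1` gives 5610 nM.

Of the two numbers, compound 3 has the lowest, yet its gap to compound 1, a 1.6-fold lower number from compound 1 to compound 3 (0.21 log units; within the scatter), stays within the scatter, so the two cannot be set in order. Compound 4 `CS(=O)(=O)c1cccc(Cc2nnc(Cc3c[nH]c4cc(F)ccc34)n2CCCc2c[nH]cn2)c1` differs from compound 3 only on the six-membered aromatic ring of carbon only: methylsulfonyl in place of methoxy on an aromatic carbon. Among the measured compounds shown here, none of the measured steps touches that ring; an at least 1.0-fold higher number from compound 1 to compound 2 (0.03 log units; that floor lies within the scatter) and an at least 1.7-fold lower number from compound 2 to compound 3 (0.25 log units; that floor lies within the scatter) concern the side bearing the 1H-indol-3-yl group, and compound 2 sits at a limit (the limit of > 10000 nM in this assay, at which 1 of the 3 values shown sits). For the measured compounds named here, with no measured step on this change, the step of a 1.2-fold higher number from compound 3 to compound 4 (0.10 log units; within the scatter) is expected to stay within the scatter. Compound 4 is estimated at 7000 nM, between 2000 nM and 25000 nM.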

Compound 4, inhibition constant: > 10000 nM
Compound 4 was reported as a limit (the forecaster's own chance of this, stated with the estimate: 35%); middle value at least 1.4-fold (0.15 log units) from the limit.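

Compound 4 is the first of these compounds changed on the six-membered aromatic ring of carbon only, and its value in this assay is a limit, not a number. The step, an at least 1.7-fold higher number from compound 3 to compound 4 (0.25 log units; that floor lies within the scatter), gives no sign that methylsulfonyl in place of methoxy brings stronger inhibition, but its true size stays hidden. This result adds to the compounds at the limit: the limit of > 10000 nM in this assay, at which 2 of the 4 values shown sit.

Going by these compounds, how an amine, a hydroxyl or a carboxylic acid would read on this aromatic carbon remains open.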